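The source may hold more compounds than are shown below. What is called first, only, known or untested is meant among the compounds shown, and "the series" means these compounds.

Two measured compounds frame this step. Compound 1, with structure `COc1ccc(N(C)c2nc(C)nc3ccccc23)cc1OCCN`, was tested in a functional assay on MDA-MB-231 cells (Homo sapiens) for inhibition, read by MTT assay, with a stated time of 48 h (on this read-out lower numbers stand for stronger inhibition and higher numbers for weaker inhibition), where compound 1 gives 682 nM. Compound 2, with structure `C[Se]c1ccc(N(C)c2nc(C)nc3ccccc23)cc1C`, was tested in the same way, and in this assay compound 2 gives 7 nM. On these two numbers compound 1 stands highest, meaning the weaker inhibitor of the pair; the gap to compound 2 is far beyond the usual scatter of such measurements.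

The new compound, compound 3, has structure `COc1ccc(N(C)c2nc(C)nc3ccccc23)cc1OCCCCCC[Se]C#N`. It is derived from compound 1 by one change, counted as a group of 7 heavy atoms (5 carbon, 1 nitrogen, 1 selenium; no ring) in place of one nitrogen atom, on a saturated chain carbon, two bonds along the chain from an oxygen on an aromatic ring.

Within the data shown here, no measured pair shows this exact change, so any expectation must rest on the two values alone. Compound 2 carries a selenium atom and gives 7 nM, which suggests that introducing selenium into the shared core can go together with strong inhibition. An estimated step of an 8.5-fold lower number from compound 1 to compound 3 (0.93 log units; beyond the scatter) in this assay is therefore expected, toward stronger inhibition and beyond the scatter. For compound 3 the expected value in this assay is 80 nM, with a range from 15 nM to 400 nM.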

Compound 3, half-maximal inhibitory concentration: 3550 nM
Compound 3: the middle estimate sits 44-fold (1.65 log units) below what was measured; measured number outside the range, above it.
By their numbers in this assay, from the lowest: compound 2; then compound 1; then compound 3.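

In this assay, replacing the amino group with the group of 7 heavy atoms containing selenium and a triple bond gives a 5.2-fold higher number from compound 1 to compound 3 (0.72 log units; beyond the scatter), which takes inhibition in the weaker direction. At this place, on a saturated chain carbon, two bonds along the chain from an oxygen on an aromatic ring, selenium in the entering group therefore does not bring stronger inhibition, although the step is modest and compound 3 still has a measurable value of 3550 nM. No measurement at hand explains why inhibition weakens with this change.

This single step removes the amino group and also adds the chain carbons, the selenium and the nitrile, so the compounds shown cannot tell which of these parts accounts for the higher number. Separating them would take close relatives of compound 1, such as a shorter chain ending in the same selenium and nitrile group, or the long chain of compound 3 ending instead in an amine or a carboxylic acid.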